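Aryl swap on an amide nitrogen: little movement so far

A few compounds are considered here, and "the series" means these few. Any claim that something is new, unique, unknown or untested is made for them only; others in the source may bear on it.

- compound 1 `CN(C)C(=O)c1cc2cnc(Nc3ccc(NC(=O)C4(C(=O)Nc5ccc(F)cc5)CC4)cc3)nc2n1C1CCCC1` gives 90.8%
- compound 2 `CN(C)C(=O)c1cc2cnc(Nc3ccc(NC(=O)C4(C(=O)Nc5ccccc5F)CC4)cc3)nc2n1C1CCCC1` gives 89.6%
- compound 3 `CN(C)C(=O)c1cc2cnc(Nc3ccc(NC(=O)C4(C(=O)Nc5ccc(Cl)c(C(F)(F)F)c5)CC4)cc3)nc2n1C1CCCC1` gives 90.4%

In a functional assay on NCI-H1299 cells (Homo sapiens) for inhibition, read by CCK-8 assay, with a stated time of 72 h, tested at 10 uM (on this read-out lower numbers stand for less inhibition of growth and higher numbers for more inhibition of growth at the one concentration tested), compound 3 gives 90.4% and so sits within the scatter of both other compounds (the steps are a number 0.4 percentage points lower from compound 1 to compound 3 (within the scatter) and a number 0.8 percentage points higher from compound 2 to compound 3 (within the scatter)). The next structure, compound 4 `CN(C)C(=O)c1cc2cnc(Nc3ccc(NC(=O)C4(C(=O)Nc5cccc(Br)c5)CC4)cc3)nc2n1C1CCCC1` carries 3-bromophenyl in place of 4-chloro-3-(trifluoromethyl)phenyl on an amide-type nitrogen. The measured swaps at this place bear on it: the two just given and also a number 1.2 percentage points lower from compound 1 to compound 2 (within the scatter) stayed within the scatter. Among the compounds with values here, no measured compound carries 3-bromophenyl. Even so, no step beyond the scatter is expected in this assay (the estimate is a number 1.4 percentage points lower from compound 3 to compound 4 (within the scatter)). The estimate for compound 4 is 89% with an expected range of 80% to 96% on this measure.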

Compound 4, percent growth inhibition at one concentration: 77.5%
Beside the measured number, compound 4's estimate is 11.5 percentage points above it; the measured number lies below the stated range.
By their numbers in this assay, from the lowest: compound 4; then compounds 2, 3 and 1 (each within the scatter of the next).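

In this assay, within the data shown here, the 3-bromophenyl group brings a number 12.9 percentage points lower from compound 3 to compound 4 (beyond the scatter) and a number 12.1 percentage points lower from compound 2 to compound 4 (beyond the scatter) and a number 13.3 percentage points lower from compound 1 to compound 4 (beyond the scatter) and these are the first steps at this place beyond the scatter. The amide-type nitrogen therefore does not accept every aryl group equally, although the size of each step is modest. No measurement shown explains this loss.

As far as these compounds go, it remains open whether the loss follows the bromine itself or the 3-bromophenyl group as a whole. A plain phenyl or a 3-chlorophenyl group on this nitrogen could help separate the two.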